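Trifluoromethyl Added to a Pair Sitting at the Assay Limit

The source may hold more compounds than are shown below. What is called first, only, known or untested is meant among the compounds shown, and "the series" means these compounds.

Compound 1, `O=C(CCN[C@@H]1CCN(c2ccc([N+](=O)[O-])cc2)C1)c1csc2ccccc12`, gives only a limit of > 100000 nM in an assay on HEK293 cells for displacement of a labelled ligand from 5-hydroxytryptamine receptor 7 (Homo sapiens), read by scintillation counting, with a stated time of 1 h; on this read-out higher numbers stand for weaker inhibition and lower numbers for stronger inhibition.
Compound 2, `O=C(CCN[C@H]1CCN(c2ccc([N+](=O)[O-])cc2)C1)c1csc2ccccc12`, likewise gives only a limit of > 100000 nM in this assay.

For the measured compounds named here, compound 2 thus stands not at a number but at a limit of this assay, and the one other value shown is a limit as well (the limit of > 100000 nM in this assay, at which 2 of the 2 values shown sit). Going by the values given here, the only measured step, a step that the two limits leave unreadable from compound 1 to compound 2, cannot be read in size or direction because the limit of > 100000 nM in this assay, at which 2 of the 2 values shown sit, leaves both ends open; the two compounds differ solely in configuration as drawn (the fact that compounds 1 and 2 differ only in the configuration as drawn).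

Compound 3, `O=C(CCN[C@H]1CCN(c2ccc([N+](=O)[O-])cc2C(F)(F)F)C1)c1csc2ccccc12`, differs from compound 2 by trifluoromethyl in place of hydrogen on an aromatic carbon. Among the compounds with values here, no measured step touches this kind of change, and the one step that exists is unreadable, so nothing in the data points to a gain or a loss beyond the scatter. Compound 3 is therefore expected to remain at or near the limit, with a number no higher from compound 2 to compound 3 (the limit leaves the size open) estimated as essentially no readable movement. The estimate for compound 3 in this assay is 100000 nM, within a range from 20000 nM to 300000 nM.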

Compound 3, inhibition constant: > 100000 nM
Compound 3 ended at the assay's limit (the forecaster's own chance of this, stated with the estimate: 70%); the middle value lies on the limit itself.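

Compound 3 stands at a limit in this assay, as compound 2 does, so the step between compound 2 and compound 3 cannot be read in size or direction. The compounds shown leave open whether trifluoromethyl in place of hydrogen on an aromatic carbon, or the configuration as drawn, makes any difference to inhibition in this assay.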